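From Pyridin-3-yl to Pyridin-4-yl on a Carbonyl Carbon

The source may report more compounds than this note shows. Statements on the series, on what has been measured and on what is new or still open speak of the compounds shown alone.

Going by the values given here, in a functional assay on RAW264.7 cells (Mus musculus) for inhibition (a lower number here means a stronger inhibitor, a higher number a weaker inhibitor), compound 1 `Cc1ccc(S(=O)(=O)NC(=O)c2cccnc2)cc1` gives 8800 nM and holds the higher of the two numbers measured so far, which makes it the weaker inhibitor of the pair. Among the compounds with values here, the only other measured compound is compound 2 `O=C(NS(=O)(=O)c1ccccc1)c1cncc(C(=O)NS(=O)(=O)c2ccccc2)c1` with 2600 nM as its value, and the gap between the two lies beyond the usual scatter. The two compounds differ in more than one place, and that gap tells little about any single change.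

Compound 3 `Cc1ccc(S(=O)(=O)NC(=O)c2ccncc2)cc1` is still unmeasured in this assay and differs from compound 1 by one swap: pyridin-4-yl in place of pyridin-3-yl on a carbonyl carbon with pyridin-4-yl in place of pyridin-3-yl on a carbonyl carbon. Within the data shown here, no measured pair shows what a single change like this does. The estimated 1.3-fold lower number from compound 1 to compound 3 (0.10 log units; within the scatter) is expected to stay within the scatter, with no clear direction. Compound 3 is estimated at 7000 nM with 2500 nM to 20000 nM as the expected range.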

Compound 3, half-maximal inhibitory concentration: 9800 nM
Compound 3: middle estimate off by 1.4-fold (0.15 log units), on the low side; measured number inside the range.
By their numbers in this assay, from the lowest: compound 2; then compounds 1 and 3 (each within the scatter of the next).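

Going by these compounds alone, the swap of pyridin-3-yl for pyridin-4-yl on a carbonyl carbon gives the first step here that changes one place only, and in this assay it reads as a 1.1-fold higher number from compound 1 to compound 3 (0.05 log units; within the scatter) on the shared core. Compound 1 and compound 3 therefore cannot be told apart in this measurement, so for this pair the choice between these two rings at this place makes no visible difference. No outside measurement is available to explain this result.

This single step says nothing about rings or groups of a different kind at the same place, such as pyridin-2-yl, a cyclohexyl ring or a longer alkyl chain. The gap to compound 2 also stays unexplained, since that compound differs from the others in more than one place.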